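The source may report more compounds than this note shows. Statements on the series, on what has been measured and on what is new or still open speak of the compounds shown alone.

Of the compounds shown here, three measured so far share one core. Compound 1 `O=C(CN1CN(c2ccccc2)C2(CCN(C(=O)c3ccc(C4CCCCC4)cc3)CC2)C1=O)NCCCCO` in an assay on HEK293 cells for displacement of a labelled ligand from NPC1-like intracellular cholesterol transporter 1 (Homo sapiens) (on this read-out lower numbers stand for stronger inhibition and higher numbers for weaker inhibition), gives 10300 nM, the lowest of the three numbers. Compound 3 `CC(C)(C)c1ccc(C(=O)N2CCC3(CC2)C(=O)N(CC(=O)NCCCCO)CN3c2ccccc2)cc1` in this assay gives 19200 nM, and compound 2 `CC(C)(C)c1ccc(C(=O)N2CCC3(CC2)C(=O)N(CC(=O)N2CCNCC2)CN3c2ccccc2)cc1` in this assay gives 22000 nM. The step of a 1.9-fold higher number from compound 1 to compound 3 (0.27 log units; within the scatter) lies within the scatter, whereas the gap from compound 1 to compound 2 lies just beyond it. The step of a 1.1-fold lower number from compound 2 to compound 3 (0.06 log units; within the scatter) also lies within the scatter.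

Compound 4 `CC(C)(C)OC(=O)NCNC(=O)CN1CN(c2ccccc2)C2(CCN(C(=O)c3ccc(C4CCCCC4)cc3)CC2)C1=O` differs from compound 1 by (tert-butoxycarbonyl)amino in place of 3-hydroxypropyl on a saturated chain carbon bound to an amide-type nitrogen. Within the data shown here, no measured step alters this position in this way. The nearest comparison is the step of a 1.1-fold lower number from compound 2 to compound 3 (0.06 log units; within the scatter), an exchange on a carbonyl carbon that left the number essentially unchanged. On that basis compound 4 is expected to give a 1.2-fold higher number from compound 1 to compound 4 (0.07 log units; within the scatter), a step not beyond the scatter. Compound 4 is therefore estimated in this assay at 12000 nM, with a range from 4000 nM to 36000 nM.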

Compound 4, half-maximal inhibitory concentration: 1700 nM
The estimate for compound 4 lay 7.1-fold (0.85 log units) above the measured number; the measured number lies below the stated range.
By their numbers in this assay, from the lowest: compound 4; then compounds 1, 3 and 2 (each within the scatter of the next, the first and the last beyond it).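

The exchange of 3-hydroxypropyl for (tert-butoxycarbonyl)amino on a saturated chain carbon bound to an amide-type nitrogen gives a 6.1-fold lower number from compound 1 to compound 4 (0.78 log units; beyond the scatter) in this assay and is the first change at this position among the compounds shown. Unlike the exchange on the aromatic carbon and the one on the carbonyl carbon, both of which stayed within the scatter, it moves the number beyond the scatter, so this position can change the read-out. No measurement shown here bears on what lies behind this step.

From the compounds shown here alone, it remains open whether the step needs the whole (tert-butoxycarbonyl)amino group or would persist with a free amine, a carboxylic acid or a longer chain at this position. Going by these compounds, it also remains open whether the same exchange would lower the number on the tert-butyl compounds.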